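Methoxy for Methyl Repeated on a Shared Core

The source may report more compounds than this note shows. Statements on the series, on what has been measured and on what is new or still open speak of the compounds shown alone.

Of the compounds shown here, three built on one core have been measured in a functional assay on B16-F10 cells (Mus musculus) for antiproliferative activity, read by MTT assay, with a stated time of 48 h; on this read-out higher numbers stand for weaker inhibition and lower numbers for stronger inhibition. Compound 1 `COc1ccc(-c2nn(-c3ccccc3)cc2CNc2ccc(C)cc2)cc1` gives 8380 nM, compound 2 `Cc1ccc(NCc2cn(-c3ccccc3)nc2-c2ccc(C)cc2)cc1` gives 7380 nM, and compound 3 `Cc1ccc(-c2nn(-c3ccccc3)cc2CNc2ccc(Cl)cc2)cc1` gives 6010 nM. Compound 2 and compound 1 differ by methoxy in place of methyl on an aromatic carbon, which brought a 1.1-fold higher number from compound 2 to compound 1 (0.06 log units; within the scatter). Compound 2 and compound 3 differ by chloro in place of methyl on an aromatic carbon, which brought a 1.2-fold lower number from compound 2 to compound 3 (0.09 log units; within the scatter); this is also how the core of compound 3 differs from that of compound 2. Compound 4 `COc1ccc(-c2nn(-c3ccccc3)cc2CNc2ccc(Cl)cc2)cc1` is not yet measured. It differs from compound 3 by methoxy in place of methyl on an aromatic carbon, the same change made from compound 2 to compound 1, at the same place. Because the earlier step showed a 1.1-fold higher number from compound 2 to compound 1 (0.06 log units; within the scatter), compound 4 is expected to land close to compound 3, with an estimated 1.1-fold higher number from compound 3 to compound 4 (0.04 log units; within the scatter). Compound 4 is thus estimated at 6600 nM, expected between 3500 nM and 12500 nM.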

Compound 4, half-maximal inhibitory concentration: 7180 nM
Estimate against measurement, compound 4: 1.1-fold (0.04 log units) below; low and high end bracket the measured number.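

In this assay, among these compounds, methoxy in place of methyl gave a 1.2-fold higher number from compound 3 to compound 4 (0.08 log units; within the scatter), and this agrees with the same change on the other core: the same change on two cores in this assay, a 1.1-fold higher number (0.06 log units; within the scatter) from compound 2 to compound 1 and a 1.2-fold higher number (0.08 log units; within the scatter) from compound 3 to compound 4, 1.1-fold (0.02 log units) apart, within the scatter of two such steps Chloro in place of methyl gave a 1.2-fold lower number from compound 1 to compound 4 (0.07 log units; within the scatter), which likewise agrees with its earlier counterpart: the same change on two cores in this assay, a 1.2-fold lower number (0.09 log units; within the scatter) from compound 2 to compound 3 and a 1.2-fold lower number (0.07 log units; within the scatter) from compound 1 to compound 4, 1.1-fold (0.02 log units) apart, within the scatter of two such steps Both changes thus carried from one core to the other without a visible difference, but every step lies within the scatter, so this shows only that these swaps left the number about where it was, not that either group has an effect of its own or that the agreement would hold on other cores.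

The compounds shown leave open whether an amine, a carboxylic acid or a longer chain at the same place would move the number beyond the scatter.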